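Bromine on the fused ring of compound 3

The compounds below may be only part of what the source reports. "The series", "measured", "known", "first", "only" and "open" are said of these compounds alone.

Compound 3 `CN(C)c1ccc(C2CC(c3ccccc3)=NN2C2=NC(=O)/C(=C3\C(=O)Nc4ccccc43)S2)cc1` is the weakest of the three measured compounds in a functional assay on cells (Melanoma cell, Homo sapiens) for cytotoxicity, read by sulforhodamine B assay, with a stated time of 48 h (a lower number here means a stronger inhibitor of growth, a higher number a weaker inhibitor of growth), giving 29400 nM. Compound 1 `O=C1N=C(N2N=C(c3ccccc3)CC2c2ccccc2O)S/C1=C1/C(=O)Nc2ccc(Br)cc21` gives 660 nM and compound 2 `COc1ccc(C2CC(c3ccccc3)=NN2C2=NC(=O)/C(=C3\C(=O)Nc4ccc(Br)cc43)S2)cc1` gives 550 nM. The gap from compound 3 to each of these two compounds lies well outside the usual scatter. Compound 4 `CN(C)c1ccc(C2CC(c3ccccc3)=NN2C2=NC(=O)/C(=C3\C(=O)Nc4ccc(Br)cc43)S2)cc1` differs from compound 3 by bromo in place of hydrogen on an aromatic carbon. For the measured compounds named here, no measured step isolates this change: compounds 1 and 2 both carry the bromo group but also differ from compound 3 at the pendant aryl, and the one measured step, a 1.2-fold lower number from compound 1 to compound 2 (0.08 log units; within the scatter), concerns that aryl alone. The gap between compound 3 and compounds 1 and 2 therefore cannot be assigned to the bromo group with confidence, so compound 4 is expected to land somewhere between them, a step of a 5.9-fold lower number from compound 3 to compound 4 (0.77 log units; beyond the scatter). Compound 4 is estimated at 5000 nM, with a range from 1000 nM to 30000 nM.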

Compound 4, concentration for total growth inhibition: 460 nM
For compound 4 the middle estimate is 11-fold (1.04 log units) above the measured one; the whole stated range lies above it.
By their numbers in this assay, from the lowest: compounds 4, 2 and 1 (each within the scatter of the next); then compound 3.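

The bromo group on the aromatic carbon of the fused system now stands alone as the change in one measured pair: in this assay it gives a 64-fold lower number from compound 3 to compound 4 (1.81 log units; beyond the scatter), so the large gap belongs to this group, at least with the dimethylamino aryl. Among the compounds carrying bromo, the pendant aryl shows no separation, with a 1.2-fold lower number from compound 2 to compound 4 (0.08 log units; within the scatter) and a 1.4-fold lower number from compound 1 to compound 4 (0.16 log units; within the scatter) both within the scatter. No measurement shown here explains the size of the bromo step. As far as these compounds go, whether chloro or a methyl group on this carbon would match bromo stays open, as does whether the bromo step holds with the methoxy or hydroxy aryl.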